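The compounds below may be only part of what the source reports. "The series", "measured", "known", "first", "only" and "open" are said of these compounds alone.

Measured so far in an ADME assay on Vero cells (Chlorocebus sabaeus) for cytotoxicity, read by resazurin assay, with a stated time of 3 days; a higher number here means a weaker inhibitor, a lower number a stronger inhibitor:
compound 1, `COc1ccc(C(=O)Nc2cc3nc(C4CCCCC4)[nH]c3cc2N(C)C)cc1`: > 100 ug/mL
compound 2, `O=C(Nc1cc2nc(C3CCCCC3)[nH]c2cc1N1CCCC1)c1ccc(Br)cc1`: > 100 ug/mL
compound 3, `CCN(CC)c1cc2[nH]c(C3CCCCC3)nc2cc1NC(=O)c1cccc(Br)c1`: > 100 ug/mL

Compound 1 in this assay sits at a limit of the assay, > 100 ug/mL, not at a number. Compound 2 likewise stops at a limit, > 100 ug/mL. Compound 3 also gives only a limit, > 100 ug/mL. Going by the values given here, all three values therefore stand at the limit of > 100 ug/mL in this assay, at which 3 of the 3 values shown sit, and no step between measured compounds can be read. Compound 4, `CN(C)c1cc2[nH]c(C3CCCCC3)nc2cc1NC(=O)c1ccc(F)cc1F`, remains to be tested; it differs from compound 1 by 2,4-difluorophenyl in place of 4-methoxyphenyl on a carbonyl carbon. With every measured value at the limit, the step is expected to be none beyond the scatter, a number no higher from compound 1 to compound 4 (the limit leaves the size open). Compound 4 is expected in this assay to reach only the limit again, estimated at 100 ug/mL with a range of 50 ug/mL to 200 ug/mL.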

Compound 4, half-maximal inhibitory concentration: > 100 ug/mL
Compound 4: no number, only a limit; the forecaster's own chance of this, stated with the estimate: 85%; the middle value sits exactly at the limit.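

No step can be read between compound 1 and compound 4 in this assay, since each gives only a limit: the limit of > 100 ug/mL in this assay, at which 4 of the 4 values shown sit.

The compounds shown leave open how far any of them lies from that limit, and so whether 2,4-difluorophenyl in place of 4-methoxyphenyl changes the read-out at all.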